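The source may hold more compounds than are shown below. What is called first, only, known or untested is meant among the compounds shown, and "the series" means these compounds.

Of the compounds shown here, two have so far been measured in an ADME assay on microsomes from liver (Homo sapiens) for metabolic stability; a higher number here means faster removal of the compound, a lower number slower removal. Compound 1 `CCCC(Oc1ccc(-n2cc3ccccc3n2)cc1)c1ccc(C(=O)NCCC(=O)O)cc1` gives 44 mL/min/kg, and compound 2 `CC(C)CC(Oc1ccc(-n2cc(C(F)(F)F)cn2)cc1)c1ccc(C(=O)NCCC(=O)O)cc1` gives 23 mL/min/kg. These two values lie within the usual scatter of each other, so on these numbers compound 2 cannot be told apart from compound 1. Compound 3 `CCCC(Oc1ccc(-n2cc(C(F)(F)F)cn2)cc1)c1ccc(C(=O)NCCC(=O)O)cc1` has not yet been measured. It differs from compound 2 in one place: hydrogen in place of methyl on a saturated chain carbon bound to two saturated chain carbons, with hydrogen in place of methyl on a saturated chain carbon bound to two saturated chain carbons, which turns isobutyl into propyl. Among the measured compounds shown here, no measured pair differs in only one place, so the data offer no direct guide to this change. With so small a change, no shift beyond the scatter is expected in this assay. The expected step of a 1.1-fold higher number from compound 2 to compound 3 (0.05 log units; within the scatter) stays inside that scatter. For compound 3 the estimated value is 26 mL/min/kg, with an expected range of 14 mL/min/kg to 46 mL/min/kg.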

Compound 3, clearance in the Homo sapiens assay: 16 mL/min/kg
Estimate against measurement, compound 3: 1.6-fold (0.21 log units) above; measured number inside the range.
By their numbers in the Homo sapiens assay, from the lowest: compounds 3, 2 and 1 (each within the scatter of the next, the first and the last beyond it).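

Removing the methyl that turns isobutyl into propyl leaves the Homo sapiens assay with a 1.4-fold lower number from compound 2 to compound 3 (0.16 log units; within the scatter), so at this chain carbon the change cannot be told apart from no change in that assay. The same change does register in a physicochemical assay for lipophilicity, using the shake flask method, at pH 7.4 (on this read-out higher numbers stand for higher lipophilicity and lower numbers for lower lipophilicity), where compound 2 gives 3.2 and compound 3 gives 2.4: the measured distribution coefficient of compound 2, 3.2, and of compound 3, 2.4, a number 0.80 log units lower (beyond the scatter). Among the compounds shown here, with the propyl chain held the same, the Homo sapiens assay shows a 2.8-fold lower number from compound 1 to compound 3 (0.44 log units; beyond the scatter) when 4-(trifluoromethyl)-1H-pyrazol-1-yl replaces 2H-indazol-2-yl on an aromatic carbon, the only step in this assay that lies beyond the scatter.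

On these data alone, this rests on a single pair for the chain change, so it remains open whether a lower distribution coefficient at this position goes with slower removal at all. Also open, as far as these compounds go, is how the Homo sapiens assay would respond to a longer chain, or to an amine or a carboxylic acid, at this chain carbon.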